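Swapping a methylpyridine ring for a methylphenyl ring

The source may report more compounds than this note shows. Statements on the series, on what has been measured and on what is new or still open speak of the compounds shown alone.

Compound 1 `N#Cc1c(-c2ccc(Br)cc2)nc2cnccc2c1NCC(N)=O` and compound 2 `CC[C@@H](Nc1c(C#N)c(-c2ccc(-c3ccncc3C)cc2)nc2cnccc12)C(N)=O` share one core. In a physicochemical assay for lipophilicity, read by HPLC, at pH 7.5 (on this read-out higher numbers stand for higher lipophilicity and lower numbers for lower lipophilicity), compound 1 gives 1.9. In this assay compound 2 gives 2, a value that sits within the usual scatter of the number for compound 1, so the two cannot be told apart on this read-out. Going by the values given here, no step between measured compounds is available to guide a change of the kind that follows.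

Compound 3 `CC[C@@H](Nc1c(C#N)c(-c2ccc(-c3ccccc3C)cc2)nc2cnccc12)C(N)=O` differs from compound 2 in one place: 2-methylphenyl in place of 3-methylpyridin-4-yl on an aromatic carbon. The ring that leaves holds one hetero atom and one hydrogen-bond acceptor; the ring that enters is of carbon only, with no hydrogen-bond acceptor. The step of a number 1.20 log units higher from compound 2 to compound 3 (beyond the scatter) is therefore expected to be upward and clearly beyond the scatter. Compound 3 is estimated at 3.2, with a range from 2.6 to 3.8.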

Compound 3, distribution coefficient: 3
For compound 3 the middle estimate is 0.20 log units above the measured one, within the range that was stated.
By their numbers in this assay, from the lowest: compounds 1 and 2 (each within the scatter of the next); then compound 3.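

Going by these compounds alone, compound 2 and compound 3 are the first pair here that differ in one place, so this is the first clean reading of this position. In this assay, putting 2-methylphenyl in place of 3-methylpyridin-4-yl, on an aromatic carbon para to a large group, gives a number 1.00 log units higher from compound 2 to compound 3 (beyond the scatter). The two groups have the same number of heavy atoms, so this position can register a clear step even when the group's size, counted in heavy atoms, stays the same, though nothing shown accounts for the size of this step.

The compounds shown leave open how the reading would move with a morpholine, a carboxylic acid or an unsubstituted phenyl ring at this position. They also leave open whether the same exchange would give a similar step on a different core.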